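From Methyl to Pyrimidin-5-yl: An Expected Inhibition Value

The source may hold more compounds than are shown below. What is called first, only, known or untested is meant among the compounds shown, and "the series" means these compounds.

Compound 1, `Cc1cc(C)c(N2CCN(c3ncccn3)CC2)nn1`, in a functional assay on BV-2 cells (Mus musculus) for inhibition, read by ELISA, with a stated time of 16 h (a lower number here means a stronger inhibitor, a higher number a weaker inhibitor), gives > 100000 nM, which is a limit of the assay and not a number.
Compound 2, `COc1ccc(-c2cc(C)c(N3CCN(c4ncccn4)CC3)nn2)cc1`, gives 5200 nM.
Compound 3, `Cc1cc(-c2ccncc2)nnc1N1CCN(c2ncccn2)CC1`, gives > 100000 nM, again a limit.

Compound 1 therefore sits at the limit of > 100000 nM in this assay, at which 2 of the 3 values shown sit, without a measured number of its own. Compound 4, `Cc1cc(-c2cncnc2)nnc1N1CCN(c2ncccn2)CC1`, differs from it by pyrimidin-5-yl in place of methyl on an aromatic carbon. The measured steps show an at least 19-fold lower number from compound 1 to compound 2 (1.28 log units; beyond the scatter) and an at least 19-fold higher number from compound 2 to compound 3 (1.28 log units; beyond the scatter), while a step that the two limits leave unreadable from compound 1 to compound 3. Pyrimidin-5-yl, like pyridin-4-yl, is a six-membered aromatic ring carrying ring nitrogen, so the nearest comparison is compound 3 rather than compound 2. Compound 4 is thus expected to give 100000 nM, within 20000 nM to 500000 nM, most likely reported again only as a limit, which means an expected step of a number no higher from compound 1 to compound 4 (the limit leaves the size open).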

Compound 4, half-maximal inhibitory concentration: > 100000 nM
Compound 4: no number, only a limit; the forecaster's own chance of this, stated with the estimate: 70%; the middle value lies on the limit itself.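

In this assay, a second kind of ring carrying ring nitrogen now fails to match 4-methoxyphenyl at this position, with an at least 19-fold higher number from compound 2 to compound 4 (1.28 log units; beyond the scatter). Pyrimidin-5-yl thus leaves compound 4 with only a limit, like compound 3, and among the compounds shown only compound 2 gives a number: the limit of > 100000 nM in this assay, at which 3 of the 4 values shown sit. The steps among compound 1, compound 3 and compound 4 join two limits and cannot be read.

On these data alone, what plain phenyl would give here remains open. So does whether an amine or a carboxylic acid in place of the methoxy group on the phenyl ring of compound 2 would keep a measurable value.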